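Removing the bromoacrylamide from a thiazolidinedione series

This account rests on a few compounds, and the source may have more. Where it says the series, first, only, none or still open, it means among the compounds named here.

Of the compounds shown here, three sharing one core have been measured in a functional assay on HeLa cells (Homo sapiens) for cytotoxicity, read by cell counting, with a stated time of 4 days; on this read-out lower numbers stand for stronger inhibition and higher numbers for weaker inhibition. Compound 1 `C=C(Br)C(=O)Nc1cccc(/C=C2\SC(=O)N(Cc3ccc(Cl)cc3)C2=O)c1` gives 2700 nM, compound 2 `C=C(Br)C(=O)Nc1cccc(/C=C2\SC(=O)N(Cc3ccc(C)cc3)C2=O)c1` gives 1200 nM, and compound 3 `C=C(Br)C(=O)Nc1cccc(/C=C2\SC(=O)N(Cc3ccccc3)C2=O)c1` gives 1400 nM. Compound 2 shows the lowest number of the three: the step of a 2.3-fold lower number from compound 1 to compound 2 (0.35 log units; beyond the scatter) lies beyond the scatter, whereas compound 2 and compound 3 sit within the scatter of each other, as does the step of a 1.9-fold lower number from compound 1 to compound 3 (0.29 log units; within the scatter).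

Compound 4 `Cc1ccc(CN2C(=O)S/C(=C\c3cccc(N)c3)C2=O)cc1` differs from compound 2 in a different part of the molecule: hydrogen in place of (1-bromoethenyl)carbonyl on a nitrogen on an aromatic ring. Among the measured compounds shown here, none of the measured steps touches this group; all three concern the substituent on the benzyl ring, so they give no direct guide to how large the step should be. The change is far larger than any measured here, and the estimate for compound 4 therefore carries wide uncertainty. Compound 4 is expected to give a higher number, estimated at 20000 nM with a range from 3000 nM to 100000 nM, a step of a 17-fold higher number from compound 2 to compound 4 (1.22 log units; beyond the scatter) in this assay.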

Compound 4, half-maximal inhibitory concentration: 98000 nM
Compound 4: the middle estimate sits 4.9-fold (0.69 log units) below what was measured; the measured number falls inside the stated range.
By their numbers in this assay, from the lowest: compounds 2, 3 and 1 (each within the scatter of the next, the first and the last beyond it); then compound 4.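

Replacing the (1-bromoethenyl)carbonyl on the nitrogen with hydrogen, which leaves a plain amino group, gives an 82-fold higher number from compound 2 to compound 4 (1.91 log units; beyond the scatter) in this assay. This step is far larger than any of the steps among compound 1, compound 2 and compound 3, so in this small set the read-out depends much more on this position than on the substituent on the benzyl ring. No measurement shown here explains the size of the step.

Going by these compounds, the bromine, the double bond and the carbonyl all leave together in this one change, so which of them matters remains open. An acetyl group or an acryloyl group without the bromine on that nitrogen would help to separate their contributions.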